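Ethylamino-linked diethylamine in place of propyl chain

The source may hold more compounds than are shown below. What is called first, only, known or untested is meant among the compounds shown, and "the series" means these compounds.

Measured so far:
Compound 1 `CCCc1n[nH]c2ncnc(N3CCN(c4cc(Cl)ccc4C)CC3)c12` gives 6 nM in an assay for inhibition of ribosomal protein S6 kinase beta-1 variant D18H,T412E (Homo sapiens), read by a luciferase reporter and chemiluminescence, with a stated time of 3 h; on this read-out higher numbers stand for weaker inhibition and lower numbers for stronger inhibition.
Compound 2 `CCc1n[nH]c2ncnc(N3CCN(c4cc(Cl)cc(CCCN(CC)CC)c4C)CC3)c12` gives 3 nM in this assay.

Compound 2 holds the lower of the two numbers, but its gap to compound 1 lies within the scatter, so the two stand level. Compound 3 `CCc1n[nH]c2ncnc(N3CCN(c4cc(Cl)cc(NCCN(CC)CC)c4C)CC3)c12` carries (2-(diethylamino)ethyl)amino in place of 3-(diethylamino)propyl on an aromatic carbon. Among the compounds with values here, no step between measured compounds bears on this change; the group that enters keeps the same count of heavy atoms and the diethylamine end, so no step beyond the scatter is expected in this assay. Compound 3 is estimated at 4 nM (range 1.5 nM to 12 nM), a step of a 1.3-fold higher number from compound 2 to compound 3 (0.12 log units; within the scatter).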

Compound 3, half-maximal inhibitory concentration: 3 nM
For compound 3 the middle estimate is 1.3-fold (0.12 log units) above the measured one, and the stated range covers the measured number.
By their numbers in this assay, from the lowest: compounds 2, 3 and 1 (each within the scatter of the next).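

In this assay, swapping the 3-(diethylamino)propyl group, which sits ortho to a methyl group, for (2-(diethylamino)ethyl)amino gives no change at the digits printed from compound 2 to compound 3 (within the scatter). At this position, the read-out therefore shows no response to exchanging a chain carbon for a nitrogen, which also brings in a hydrogen-bond donor. No measurement on hand accounts for this flat step.

Compound 1 differs from compound 2 and compound 3 in more than one place, so the contribution of the side chain cannot be isolated. As far as these compounds go, a carboxylic acid or morpholine at the chain end, or a longer chain, remains open.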